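Trimming the Aryl Substituent: Isopropyl to Methyl

A few compounds are considered here, and "the series" means these few. Any claim that something is new, unique, unknown or untested is made for them only; others in the source may bear on it.

Measured so far in a functional assay on ECa-109 cells (Homo sapiens) for inhibition, read by MTT assay, with a stated time of 72 h; on this read-out lower numbers stand for stronger inhibition and higher numbers for weaker inhibition:
- compound 1 `CC(C)c1ccc(-c2nc(SCc3cn(CC(=O)NC(=O)Nc4ccccn4)nn3)nc(Nc3ccc(F)cc3)c2C#N)cc1` gives only a limit, > 64000 nM
- compound 2 `CC(C)c1ccc(-c2nc(SCc3cn(CC(=O)NC(=O)Nc4ccccn4)nn3)nc(Nc3cccc(Cl)c3)c2C#N)cc1` gives 13300 nM
- compound 3 `COc1ccc(Nc2nc(SCc3cn(CC(=O)NC(=O)Nc4ccccn4)nn3)nc(-c3ccc(C(C)C)cc3)c2C#N)cc1` gives 5420 nM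

Compound 3 stands lowest of the two numbers shown; compound 2 is nearest, the step being a 2.5-fold lower number from compound 2 to compound 3 (0.39 log units; beyond the scatter). Compound 1 sits at the limit of > 64000 nM in this assay, at which 1 of the 3 values shown sits. Compound 4 `COc1ccc(Nc2nc(SCc3cn(CC(=O)NC(=O)Nc4ccccn4)nn3)nc(-c3ccc(C)cc3)c2C#N)cc1` differs from compound 3 by methyl in place of isopropyl on an aromatic carbon. Every measured step, an at least 4.8-fold lower number from compound 1 to compound 2 (0.68 log units; beyond the scatter) and an at least 11-fold lower number from compound 1 to compound 3 (1.07 log units; beyond the scatter) among them, changes the aryl on the nitrogen, not this position, so none bears directly on the new step. A small change is therefore expected, within or near the scatter, with the larger measured shifts serving only as an upper bound. Compound 4 is estimated at 9000 nM, between 3000 nM and 30000 nM, the expected step being a 1.7-fold higher number from compound 3 to compound 4 (0.22 log units; within the scatter).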

Compound 4, half-maximal inhibitory concentration: 5870 nM
Estimate against measurement, compound 4: 1.5-fold (0.19 log units) above; the range from low to high includes it.
By their numbers in this assay, from the lowest: compounds 3 and 4 (each within the scatter of the next); then compound 2. At a limit, above all of these: compound 1.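

Replacing 4-isopropylphenyl with 4-methylphenyl gives a 1.1-fold higher number from compound 3 to compound 4 (0.03 log units; within the scatter). For the compounds shown here, this is the first measured step at this aromatic carbon, para to a large group, and it shows that methyl can stand in place of isopropyl here without a shift beyond the scatter, whereas the earlier steps all changed the aryl on the nitrogen. Nothing in the data shown gives a reason for this result.

The compounds shown leave open how an amine, a carboxylic acid or a longer chain would fare at this carbon. They also leave open whether the 3-chlorophenyl and 4-fluorophenyl compounds would respond to the same trim.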